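Two Carboxylic Acids on a Shared Peroxide Core

The source may hold more compounds than are shown below. What is called first, only, known or untested is meant among the compounds shown, and "the series" means these compounds.

Compound 1, drawn as `O=C(O)COc1c(Cl)cc([C@H]2CC[C@]3(CC2)OOC2(O3)C3CC4CC(C3)CC2C4)cc1Cl`, and compound 2, drawn as `O=C(O)CNC(=O)COc1ccc([C@H]2CC[C@]3(CC2)OOC2(O3)C3CC4CC(C3)CC2C4)cc1`, share a core and differ in the groups carried on the aromatic ring. In a physicochemical assay for lipophilicity, read by HPLC, at pH 7.4 (on this read-out lower numbers stand for lower lipophilicity and higher numbers for higher lipophilicity), compound 1 gives 3.3, and in this assay compound 2 gives 3. Compound 2 stands at the lower of the two numbers, with compound 1 lying within the usual scatter of it, so the two values cannot be ordered.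

Compound 3, drawn as `CC(C)(Oc1ccc([C@H]2CC[C@]3(CC2)OOC2(O3)C3CC4CC(C3)CC2C4)cc1)C(=O)O`, has not yet been measured. It differs from compound 2 in one place: 1-carboxy-1-methylethyl in place of ((carboxymethyl)carbamoyl)methyl on an oxygen on an aromatic ring. Because compound 2 gives 3 and the incoming group carries fewer hydrogen-bond donors and acceptors than the one it replaces, compound 3 is expected to lie higher, by an expected step of a number 0.60 log units higher from compound 2 to compound 3 (beyond the scatter). For compound 3 the estimated value in this assay is 3.6, within a range from 3 to 4.2.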

Compound 3, distribution coefficient: 3.1
The estimate for compound 3 lay 0.50 log units above the measured number, and the stated range covers the measured number.
By their numbers in this assay, from the lowest: compounds 2, 3 and 1 (each within the scatter of the next).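

On an oxygen on an aromatic ring, 1-carboxy-1-methylethyl in place of ((carboxymethyl)carbamoyl)methyl gives, in this assay, a number 0.10 log units higher from compound 2 to compound 3 (within the scatter). This first one-place comparison shows that the read-out does not separate these two groups, although the entering group has fewer heavy atoms, hydrogen-bond donors and hydrogen-bond acceptors than the leaving one. Nothing in the available findings accounts for this result.

The compounds shown leave open how a group ending in an amine, or a longer chain ending in a carboxylic acid, would read on this oxygen in this assay. Also open, on these data alone, is whether 1-carboxy-1-methylethyl in place of ((carboxymethyl)carbamoyl)methyl would give a similar step on a ring carrying the chlorine atoms of compound 1.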